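A Chloro-to-Fluoro Swap Tested a Second Time

The source may hold more compounds than are shown below. What is called first, only, known or untested is meant among the compounds shown, and "the series" means these compounds.

Three compounds were measured in a functional assay on the whole organism (artery, strain albino) with Rattus norvegicus as the target, with a stated time of 15 min, at a dose of 10 mg/kg by the oral route; a higher number here means more inhibition at the dose given (going by the name of the read-out), a lower number less inhibition. Compound 1 `COc1ccc(C2N=C(SCc3ccc(Cl)cc3)NC(C)=C2C(=O)Nc2ccc(F)cc2)cc1OC` gives 3.1% in this assay, and compound 2 `COc1ccc(C2N=C(SCc3ccc(F)cc3)NC(C)=C2C(=O)Nc2ccc(F)cc2)cc1OC` gives 3.6% in this assay. The two share one core and differ by fluoro in place of chloro on an aromatic carbon; the step of a number 0.5 percentage points higher from compound 1 to compound 2 (within the scatter) is small. Compound 3 `CC1=C(C(=O)Nc2ccc(Br)cc2)C(c2ccc(Cl)cc2Cl)N=C(SCc2ccc(Cl)cc2)N1` gives 4.1% in this assay; its core is a different one, and the difference between the two cores is not broken down here. The gaps from compound 3 to compound 1 and to compound 2 fall within the usual scatter, so none of the three stands apart.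

Compound 4 `CC1=C(C(=O)Nc2ccc(Br)cc2)C(c2ccc(Cl)cc2Cl)N=C(SCc2ccc(F)cc2)N1` carries the same change on the core of compound 3, namely (fluoro in place of chloro on an aromatic carbon), at the same place. The change is expected to behave as it did from compound 1 to compound 2, resting on a number 0.5 percentage points higher from compound 1 to compound 2 (within the scatter). The step to compound 4 is therefore estimated at a number 0.4 percentage points higher from compound 3 to compound 4 (within the scatter), and compound 4 is expected to give about 4.5% in this assay, plausibly between 0.5% and 10%.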

Compound 4, a percentage reported as inhibition, in the whole organism at one dose (the size of the read-out at that dose, not a potency): 3.6%
Compound 4: the middle estimate sits 0.9 percentage points above what was measured; low and high end bracket the measured number.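

In this assay, the same swap on the core of compound 3 reads a number 0.5 percentage points lower from compound 3 to compound 4 (within the scatter). Set beside the earlier step on the core of compound 1, the two readings do not differ, so the series gives no sign that the core alters what this change does: the same change on two cores in this assay, a number 0.5 percentage points higher (within the scatter) from compound 1 to compound 2 and a number 0.5 percentage points lower (within the scatter) from compound 3 to compound 4, 1 percentage points apart, within the scatter of two such steps This agreement shows only that the fluoro-for-chloro swap left no readable mark on either core at this one dose, so the opposite signs of the two steps should not be taken as a true reversal, and it does not show that the change would carry over in the same way where the inhibition is large enough for a step to stand clear of the scatter.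

Both steps exchange only 4-chlorobenzyl for 4-fluorobenzyl, so the compounds shown leave open what a different group in that place, such as an amine or a carboxylic acid, would do. They also leave open whether a longer chain in place of the 4-fluorobenzyl group would lift any compound clear of the others.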